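Chloro to fluoro on a cytotoxicity series at the assay limit

The compounds below may be only part of what the source reports. "The series", "measured", "known", "first", "only" and "open" are said of these compounds alone.

Compound 1, `OC[C@@H]1C[C@H](CO)[C@@H]2C(c3ccccc3Cl)=NO[C@H]12`: in a functional assay on A549 cells (Homo sapiens) for cytotoxicity, read by MTT assay, with a stated time of 48 h (a higher number here means a weaker inhibitor, a lower number a stronger inhibitor), compound 1 gives > 50 ug/mL, which is a limit of the assay rather than a number.
Compound 2, `COc1ccc(C2=NO[C@@H]3[C@H](CO)C[C@H](CO)[C@H]23)cc1OC`: in this assay compound 2 gives > 50 ug/mL, again a limit of the assay.
Compound 3, `OC[C@@H]1C[C@H](CO)[C@@H]2C(c3ccc(Cl)cc3)=NO[C@H]12`: in this assay compound 3 gives > 50 ug/mL, also a limit of the assay.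

For the measured compounds named here, compound 3 therefore stands where the other two stand: at the limit of > 50 ug/mL in this assay, at which 3 of the 3 values shown sit, with no number to compare against and no measured step to any other compound.

Compound 4, `OC[C@@H]1C[C@H](CO)[C@@H]2C(c3ccc(F)cc3)=NO[C@H]12`, is the next point. It differs from compound 3 as follows: fluoro in place of chloro on an aromatic carbon. Going by the values given here, with every measured compound sitting at the same limit, there is no step in this assay to build on, and the change is a small one on a ring substituent.

The step from compound 3 to compound 4 is expected to be none beyond the scatter, that is a step that the limit leaves unreadable from compound 3 to compound 4. Compound 4 is thus expected to give about 70 ug/mL in this assay, within the range 30 ug/mL to 200 ug/mL, and most likely to be reported again only as a limit.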

Compound 4, half-maximal inhibitory concentration: 31.1 ug/mL
For compound 4 the middle estimate is 2.3-fold (0.35 log units) above the measured one; the range from low to high includes it.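

In this assay, for the compounds shown here, compound 4 is the first compound here to give a number rather than a limit, so this position on the aromatic ring is the first place where a change can be read at all. Fluoro in place of chloro gives an at least 1.6-fold lower number from compound 3 to compound 4 (0.20 log units; that floor lies within the scatter), and the true step may be larger, but its size cannot be fixed because compound 3 gives only a limit: the limit of > 50 ug/mL in this assay, at which 3 of the 4 values shown sit. Compound 4 can now serve as a measured reference point, but it cannot be called stronger than compound 3.

On these data alone, whether a nitrile or an amine at this ring carbon would move the number further stays open. Also open, as far as these compounds go, is whether a carboxylic acid in place of either hydroxymethyl group on the shared core would change the read-out.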